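A shorter iodo-bearing arm on a triphosphate probe

This account rests on a few compounds, and the source may have more. Where it says the series, first, only, none or still open, it means among the compounds named here.

Compound 1 `O=C(CI)NCCCCC(=O)NCCCCCCNc1ncnc2c1ncn2[C@@H]1O[C@H](COP(=O)(O)OP(=O)(O)OP(=O)(O)O)[C@@H](O)[C@H]1O`: 0%
Compound 2 `CN(CCCCN(C)C(=O)CCCCNc1ncnc2c1ncn2[C@@H]1O[C@H](COP(=O)(O)OP(=O)(O)OP(=O)(O)O)[C@@H](O)[C@H]1O)C(=O)CCCCNC(=O)CI`: 0%
Compound 3 `CN(CCCCN(C)c1ncnc2c1ncn2[C@@H]1O[C@H](COP(=O)(O)OP(=O)(O)OP(=O)(O)O)[C@@H](O)[C@H]1O)C(=O)CCCCCNC(=O)CI`: 0%

All three measured compounds were tested in an assay on isolated protein for inhibition of hexokinase-1 (Rattus norvegicus), with a stated time of 6 h, tested at 10 mM; on this read-out higher numbers stand for more inhibition at the one concentration tested (going by the name of the read-out) and lower numbers for less inhibition. In this assay compound 1 gives 0%, compound 2 gives 0% and compound 3 gives 0%; compound 1 stands level with both of them at the digits shown, within the scatter, so none of the three can be called stronger or weaker. Compound 4 `O=C(I)NCC(=O)NCCCCCCNc1ncnc2c1ncn2[C@@H]1O[C@H](COP(=O)(O)OP(=O)(O)OP(=O)(O)O)[C@@H](O)[C@H]1O` differs from compound 1 in one place: a group of 4 heavy atoms (1 carbon, 1 nitrogen, 1 oxygen, 1 iodine; no ring) in place of a group of 8 heavy atoms (5 carbon, 1 nitrogen, 1 oxygen, 1 iodine; no ring), on a saturated chain carbon bound to a carbonyl carbon. Among the measured compounds shown here, no step between measured compounds is available, and the three flat values give no direction to work from. Compound 4 is therefore expected to show no step beyond the scatter, no change at the digits printed from compound 1 to compound 4 (within the scatter). The estimated inhibition of compound 4 in this assay is 0%, expected to fall between 0% and 10%.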

Compound 4, a percentage reported as inhibition, at one concentration (the size of the read-out at that concentration, not a potency): 0%
Beside the measured number, compound 4's estimate shows no gap at the digits printed; low and high end bracket the measured number.
By their numbers in this assay, from the lowest: compounds 1, 2, 3 and 4 (each within the scatter of the next).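

This first step at this position shows that the group of 4 heavy atoms on a saturated chain carbon bound to a carbonyl carbon, in place of the 3-(((iodomethyl)carbonyl)amino)propyl group, gives no change at the digits printed from compound 1 to compound 4 (within the scatter) in this assay on this one read-out. The earlier compounds shown here offered no such single-place comparison. Nothing measured here explains this result.

The compounds shown leave open whether an amine or a carboxylic acid at this position would give any inhibition in this assay. With all values level, they also leave open whether this position influences the read-out at all.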